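Compound 3 to compound 4: removing the phenyl

The compounds below may be only part of what the source reports. "The series", "measured", "known", "first", "only" and "open" are said of these compounds alone.

In a functional assay on NCI-H460 cells (Homo sapiens) for cytotoxicity, read by MTT assay, with a stated time of 72 h (on this read-out lower numbers stand for stronger inhibition and higher numbers for weaker inhibition), compound 1 `CC(C)(C)C1=CC(=O)C=CC1=O` gives > 100000 nM, which is a limit and not a number. Compound 2 `CCNC1=CC(=O)C(C(C)(C)C)=CC1=O` gives 64000 nM, and compound 3 `CC(C)(C)C1=CC(=O)C(NCc2ccccc2)=CC1=O` gives 19000 nM, the lower of the two actual numbers in the series.

Compound 4 `CNC1=CC(=O)C(C(C)(C)C)=CC1=O` is next, with hydrogen in place of phenyl on a saturated chain carbon bound to an amine nitrogen. The most relevant measured change is a 3.4-fold lower number from compound 2 to compound 3 (0.53 log units; beyond the scatter), which involves the same place and lies beyond the scatter. Here phenyl replaced methyl, so removing the phenyl is expected to reverse a similar amount. The other measured change, an at least 1.5-fold lower number from compound 1 to compound 2 (0.19 log units; that floor lies within the scatter), has a floor within the scatter and sets no size for an amine substituent. A higher number is therefore expected, with a modest step beyond the scatter. The estimated change is a 3.4-fold higher number from compound 3 to compound 4 (0.53 log units; beyond the scatter). Compound 4 could also end at the limit of the assay (the limit of > 100000 nM in this assay, at which 1 of the 3 values shown sits). Compound 4 is estimated at 65000 nM, with an expected range of 30000 nM to 100000 nM.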

Compound 4, half-maximal inhibitory concentration: 63000 nM
Compound 4: the middle estimate sits 1.0-fold (0.01 log units) above what was measured; the measured number falls inside the stated range.
By their numbers in this assay, from the lowest: compound 3; then compounds 4 and 2 (each within the scatter of the next). At a limit, above all of these: compound 1.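

In this assay the phenyl on a saturated chain carbon bound to an amine nitrogen now has a measured loss as well as a gain: a 3.3-fold higher number from compound 3 to compound 4 (0.52 log units; beyond the scatter) follows when hydrogen takes its place. Hydrogen in place of methyl at that same carbon gives a 1.0-fold lower number from compound 2 to compound 4 (0.01 log units; within the scatter) so the two small amine substituents cannot be told apart here, and within these compounds only the phenyl separates from them. The amine substituent itself remains without a size, as an at least 1.5-fold lower number from compound 1 to compound 4 (0.20 log units; that floor lies within the scatter) rests on a limit for compound 1: the limit of > 100000 nM in this assay, at which 1 of the 4 values shown sits.

Going by these compounds, whether a cyclohexyl or a longer chain at that carbon would match the phenyl stays open. Also open, on these data alone, is what a chloro or methoxy group on the phenyl, or a carboxylic acid on the chain, would do.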